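Swapping Fluoro for Cyano on Two Related Cores

This account rests on a few compounds, and the source may have more. Where it says the series, first, only, none or still open, it means among the compounds named here.

Measured so far:
Compound 1, `COc1ccc(-c2csc(N)c2C(=O)OCc2ccc(F)cc2)cc1OC`: 2%
Compound 2, `COc1ccc(-c2csc(N)c2C(=O)OCc2ccc(C#N)cc2)cc1OC`: 10%
Compound 3, `CCOC(=O)c1c(-c2cccc(F)c2)csc1N`: 38%

All three numbers come from an assay on isolated protein for inhibition of protein kinase C zeta type (Homo sapiens), with stated times of 1 h and 2.5 min, tested at 30 uM; on this read-out higher numbers stand for more inhibition at the one concentration tested (going by the name of the read-out) and lower numbers for less inhibition. Compound 1 and compound 2 share one core and differ in a single place: cyano in place of fluoro on an aromatic carbon. The step this change made is a number 8 percentage points higher from compound 1 to compound 2 (within the scatter), so the two values cannot be told apart. Compound 3 sits on a different core and is the highest of the three, beyond the scatter from both of the others. The difference between the core of compound 3 and the core of compound 1 is not broken down here.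

Compound 4 `CCOC(=O)c1c(-c2cccc(C#N)c2)csc1N` has not yet been measured in this assay. It differs from compound 3 by cyano in place of fluoro on an aromatic carbon. In compound 2 the cyano stands para to a large group, in compound 4 meta to a large group, so this is the same kind of change as before, not the same change.

For compound 4 the expected step in this assay is a number 4 percentage points higher from compound 3 to compound 4 (within the scatter), which rests on the earlier step of a number 8 percentage points higher from compound 1 to compound 2 (within the scatter) being within the scatter. The estimate for compound 4 is therefore 42%, expected to fall between 25% and 60%.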

Compound 4, a percentage reported as inhibition, at one concentration (the size of the read-out at that concentration, not a potency): 32%
Estimate against measurement, compound 4: 10 percentage points above, and the stated range covers the measured number.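

In this assay, cyano in place of fluoro on the second core gives a number 6 percentage points lower from compound 3 to compound 4 (within the scatter), so here too the change is too small to tell the two compounds apart. Set side by side, the steps on the two cores do not differ, so in these two pairs the change carries over from one core to the other as a step lost in the scatter: the same change on two cores in this assay, a number 8 percentage points higher (within the scatter) from compound 1 to compound 2 and a number 6 percentage points lower (within the scatter) from compound 3 to compound 4, 14 percentage points apart, within the scatter of two such steps. For the compounds shown here, this does not show that the swap is without effect on every core, since it rests on only two pairs, and a read-out at one concentration gives no potency and could hide a small real difference.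

The compounds shown leave open whether a different group on the same aromatic carbon, such as chloro or trifluoromethyl, would produce a step beyond the scatter. They also leave open what a carboxylic acid in place of the ester would do on either core.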